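This account rests on a few compounds, and the source may have more. Where it says the series, first, only, none or still open, it means among the compounds named here.

Compound 1 `O=S(=O)(Nc1ccc(-c2nc3ccccc3o2)cc1)c1ccccc1Cl` is a sulfonamide built on a shared core. In an ADME assay on HEK293 cells (Homo sapiens) for cytotoxicity, read by resazurin assay, with a stated time of 48 h (a lower number here means that less compound is tolerated, a higher number that more compound is tolerated), compound 1 gives > 100000 nM, which is a limit of the assay rather than a measured number. Compound 2 `O=S(=O)(Nc1ccc2oc(-c3ccccc3)nc2c1)c1ccccc1O` keeps the same core with the sulfonamide attached on another part of it and carries a hydroxyl on the outer ring; in this assay compound 2 gives 33000 nM. Going by the values given here, no step between compound 1 and compound 2 is counted here, so their two values show only that compound 1 reached the limit while compound 2 returned a number.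

Compound 3 `Cc1cccc(S(=O)(=O)Nc2ccc(-c3nc4ccccc4o3)cc2)c1` differs from compound 1 in a single place: 3-methylphenyl in place of 2-chlorophenyl on a sulfonyl sulfur. Both groups are six-membered aromatic rings of carbon only, each without hydrogen-bond donors or acceptors. Because compound 1 sits at the limit of > 100000 nM in this assay, at which 1 of the 2 values shown sits, the move from compound 1 to compound 3 can only be read against that limit, and it is expected to be no more than a number no higher from compound 1 to compound 3 (the limit leaves the size open). Compound 3 is expected to give about 100000 nM in this assay, within 30000 nM to 300000 nM, with a real chance that only a limit is reported again.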

Compound 3, half-maximal cytotoxic concentration: > 100000 nM
Compound 3: only a limit was reported; the forecaster's own chance of this, stated with the estimate: 60%; the middle value lies on the limit itself.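

Going by these compounds alone, compound 1 and compound 3 both return a limit rather than a number in this assay, and no step between them can be read: the limit of > 100000 nM in this assay, at which 2 of the 3 values shown sit. The compounds shown leave open how much of compound 1 and compound 3 is actually tolerated, and whether 3-methylphenyl and 2-chlorophenyl differ at all here.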